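The source may hold more compounds than are shown below. What is called first, only, known or untested is meant among the compounds shown, and "the series" means these compounds.

Measured so far:
Compound 1 `CCOC(=O)Cn1cc(CNC(=O)c2cn(Cc3ccccc3)nn2)nn1`: 35000 nM
Compound 2 `CC(=O)OCCn1cc(CNC(=O)c2cn(Cc3ccccc3)nn2)nn1`: 28000 nM

In a functional assay on B16 cells (Mus musculus) for cytotoxicity, read by MTT assay, with a stated time of 48 h (on this read-out lower numbers stand for stronger inhibition and higher numbers for weaker inhibition), compound 2 gives 28000 nM and compound 1 gives 35000 nM. These two values lie within the scatter of each other, so the pair cannot be ranked.

The next compound is compound 3 `CC(=O)OCCn1cc(CNC(=O)c2cn(CCOC(C)=O)nn2)nn1`. Compared with compound 2, the change is acetoxymethyl in place of phenyl on a saturated chain carbon bound to an aromatic nitrogen. In words, acetoxymethyl takes the place of phenyl on a saturated chain carbon bound to an aromatic nitrogen, which turns benzyl into 2-acetoxyethyl.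

Among the compounds with values here, only one measured step exists, a 1.3-fold lower number from compound 1 to compound 2 (0.10 log units; within the scatter). It puts acetoxymethyl in place of ethoxycarbonyl, so it shows that one swap of this kind made no clear difference. It says little about the new change, since both measured compounds keep the phenyl and no measurement shows what happens without it. The expectation is therefore loose: a modest move towards a higher number in this assay, and no move at all remains possible. The expected change is a 2.1-fold higher number from compound 2 to compound 3 (0.33 log units; beyond the scatter). For compound 3 the estimate is 60000 nM, with an expected range from 25000 nM to 150000 nM.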

Compound 3, half-maximal inhibitory concentration: > 100000 nM
Compound 3: no number, only a limit (the forecaster's own chance of this, stated with the estimate: 25%); middle value at least 1.6-fold (0.22 log units) from the limit.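

Compound 3 has no exact value in this assay, only a limit: the limit of > 100000 nM in this assay, at which 1 of the 3 values shown sits.

Even so, the step can be read. Replacing benzyl with 2-acetoxyethyl gives an at least 3.5-fold higher number from compound 2 to compound 3 (0.55 log units; beyond the scatter), so inhibition clearly weakens, and the true size of the loss may be larger than this step shows. Within the data shown here, the earlier step, a 1.3-fold lower number from compound 1 to compound 2 (0.10 log units; within the scatter), kept the phenyl in place and stayed within the scatter, so this is the first sign that the group on this saturated chain carbon bound to an aromatic nitrogen matters for the read-out.

The single step removes the phenyl and brings in the acetoxymethyl at the same time, so the compounds shown cannot tell whether losing the ring or gaining the ester-bearing chain drives the loss. A plain ethyl chain or a 2-aminoethyl group in place of benzyl would help separate these two effects.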